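The source may hold more compounds than are shown below. What is called first, only, known or untested is meant among the compounds shown, and "the series" means these compounds.

Of the compounds shown here, three built on one shared core have been tested in a functional assay on MCF7 cells (Homo sapiens) for cytotoxicity, read by MTT assay, with a stated time of 72 h; on this read-out higher numbers stand for weaker inhibition and lower numbers for stronger inhibition. Compound 1 `O=C1c2c[n+]([O-])c3ccccc3c2C(=O)c2c1c1ccccc1n2Cc1cn([C@H]2O[C@H](CO)[C@@H](O)[C@H]2O)nn1` gives 1490 nM. Going by the values given here, compound 3 `CC1(C)OC[C@H](Cn2cc(Cn3c4c(c5ccccc53)C(=O)c3c[n+]([O-])c5ccccc5c3C4=O)nn2)O1` gives 530 nM, and the step of a 2.8-fold lower number from compound 1 to compound 3 (0.45 log units; beyond the scatter) is the only change at a single point measured so far. Compound 2 `O=C1c2c[n+]([O-])c3ccccc3c2C(=O)c2c1c1ccccc1n2CCCCn1ccnc1` gives 130 nM, the lowest of the three numbers; compound 3 stands nearest to it and compound 1 furthest, both gaps beyond the scatter.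

Compound 4 `CN1CCN(CCCCCn2c3c(c4ccccc42)C(=O)c2c[n+]([O-])c4ccccc4c2C3=O)CC1` differs from compound 2 at the far end of the chain that hangs from the core: (4-methylpiperazin-1-yl)methyl in place of 1H-imidazol-1-yl on a saturated chain carbon, four bonds along the chain from an aromatic nitrogen. Among the compounds with values here, no measured step bears on this change. Within the data shown here, the single measured step, from compound 1 to compound 3, alters a different group attached directly to an aromatic nitrogen and tells nothing about swapping one ring for another out on a chain.

With nothing comparable to lean on, the expectation is that the number stays close to that of compound 2. Compound 4 is therefore expected to give 150 nM, with a likely range from 50 nM to 500 nM. That estimate corresponds to an expected step of a 1.2-fold higher number from compound 2 to compound 4 (0.06 log units; within the scatter), which is within the scatter.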

Compound 4, half-maximal inhibitory concentration: 1260 nM
Compound 4: the middle estimate sits 8.4-fold (0.92 log units) below what was measured, outside the stated range (above it).
By their numbers in this assay, from the lowest: compound 2; then compound 3; then compounds 4 and 1 (each within the scatter of the next).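

In this assay, going by these compounds alone, the far end of the chain proves to matter: the step of a 9.7-fold higher number from compound 2 to compound 4 (0.99 log units; beyond the scatter) is the first measured change out on this chain, and it lies beyond the scatter. The swap does two things at once, as the names 3-(1H-imidazol-1-yl)propyl and 4-(4-methylpiperazin-1-yl)butyl show: it replaces a five-membered aromatic ring with a six-membered non-aromatic one, and it lengthens the chain. Nothing measured here explains this step.

The compounds shown leave open which of these two alterations carries the step; a 3-(4-methylpiperazin-1-yl)propyl group in the same place, keeping the chain of compound 2, would separate them. Also open, on these data alone, is how a morpholine ring or a simple dimethylamine at the chain end would read.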